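A few compounds are considered here, and "the series" means these few. Any claim that something is new, unique, unknown or untested is made for them only; others in the source may bear on it.

Measured in an ADME assay for pharmacokinetics, read by LC-MS, in phosphate buffer, with a stated time of 120 min, at pH 7.4, tested at 1 uM, in the presence of a further agent that is not named here; a lower number here means that the compound disappears faster, a higher number that the compound lasts longer:
- compound 1 `CN(C)CC/C=C/C(=O)Nc1ccccc1`: 7.38 h
- compound 2 `C/C=C/C(=O)Nc1ccccc1`: > 8.53 h (a limit of the assay)
- compound 3 `O=C(/C=C/C(F)(F)F)Nc1ccccc1`: 0.267 h

Compound 3, at 0.267 h, holds the lowest number of the three. The number for compound 2, > 8.53 h, is a limit of the assay and not an exact value. The trifluoromethyl compound stands well apart from the other two, with a 28-fold lower number from compound 1 to compound 3 (1.44 log units; beyond the scatter) and an at least 31-fold lower number from compound 2 to compound 3 (1.50 log units; beyond the scatter), both large and beyond the scatter.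

Compound 4 `O=C(/C=C/C(F)F)Nc1ccccc1` is made from compound 3 by one change, hydrogen in place of fluoro on a saturated chain carbon bound to a double-bonded chain carbon and two fluorine atoms: hydrogen in place of fluoro, so that trifluoromethyl becomes difluoromethyl. This goes part of the way from the trifluoromethyl of compound 3 towards the methyl of compound 2, so an at least 31-fold lower number from compound 2 to compound 3 (1.50 log units; beyond the scatter) is the closest guide, read in reverse. The remaining step, an at least 1.1-fold higher number from compound 1 to compound 2 (0.06 log units; that floor lies within the scatter), lies within the scatter and involves no fluoro group, so it offers little here. A partial recovery in this assay therefore seems likely, towards longer half-life, though only part of the large gap should be regained. The expected change is a 3.7-fold higher number from compound 3 to compound 4 (0.57 log units; beyond the scatter). Compound 4 is estimated at 1 h, with an expected range from 0.35 h to 3.5 h.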

Compound 4, half-life: 0.733 h
Estimate against measurement, compound 4: 1.4-fold (0.13 log units) above, and the stated range covers the measured number.
By their numbers in this assay, from the lowest: compound 3; then compound 4; then compound 1. At a limit, above all of these: compound 2.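

The result shows that at this position a single exchange, hydrogen in place of fluoro on the saturated chain carbon bound to a double-bonded chain carbon and two fluorine atoms, already shifts the number beyond the scatter in this assay: a 2.7-fold higher number from compound 3 to compound 4 (0.44 log units; beyond the scatter). It also shows that this exchange closes only part of the gap, for difluoromethyl still leaves the half-life well short of the compounds without fluorine, with a 10-fold lower number from compound 1 to compound 4 (1.00 log units; beyond the scatter) and an at least 11-fold lower number from compound 2 to compound 4 (1.06 log units; beyond the scatter). The second of these steps is only a floor, as compound 2 holds a limit of the assay and not a number: the limit of > 8.53 h in this assay, at which 1 of the 4 values shown sits.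

The compounds shown leave open where fluoromethyl, with one fluorine atom on that carbon, would fall in this assay, and thus whether the remaining distance to methyl is covered evenly or in one large jump. They also leave open what removes these compounds in this medium, and whether the same order would hold with a chloromethyl group or a longer chain carrying fluorine atoms in that place.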